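Indole nitrogen substituent and steroid 5-alpha-reductase inhibition

The compounds below may be only part of what the source reports. "The series", "measured", "known", "first", "only" and "open" are said of these compounds alone.

Compound 1 `CC(C)=CCn1ccc2cc(/C(C)=C/C(=O)Nc3ccccc3OCCCC(=O)O)ccc21`: 120 nM
Compound 2 `CCCCC(C)n1ccc2cc(/C(C)=C/C(=O)Nc3ccccc3OCCCC(=O)O)ccc21`: 6 nM

The two measured compounds share one core and differ only at the aromatic nitrogen. In an assay on Prostate gland for inhibition of steroid 5-alpha-reductase (Rattus norvegicus) (a lower number here means a stronger inhibitor, a higher number a weaker inhibitor), compound 2 gives 6 nM, the lowest number of the two, and the step of a 20-fold lower number from compound 1 to compound 2 (1.30 log units; beyond the scatter) shows how strongly this position governs the read-out. Compound 3 `C/C(=C\C(=O)Nc1ccccc1OCCCC(=O)O)c1ccc2c(ccn2Cc2ccccc2C)c1` carries the change (2-methylbenzyl in place of 1-methylpentyl on an aromatic nitrogen). Going by the values given here, no measured step covers an aromatic group at this nitrogen; the one step from compound 1 to compound 2 only shows that exchanging the substituent there can move the number a great deal in either direction. The direction for compound 3 is therefore uncertain, and a modest loss against compound 2 is the expected outcome, a 3.3-fold higher number from compound 2 to compound 3 (0.52 log units; beyond the scatter), with wide bounds. Compound 3 is estimated at 20 nM, within 4 nM to 120 nM.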

Compound 3, half-maximal inhibitory concentration: 69 nM
Estimate against measurement, compound 3: 3.5-fold (0.54 log units) below, and the stated range covers the measured number.
By their numbers in this assay, from the lowest: compound 2; then compounds 3 and 1 (each within the scatter of the next).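

In this assay, going by these compounds alone, the first ring-bearing group at this nitrogen does not keep the level of the 1-methylpentyl group, with a 12-fold higher number from compound 2 to compound 3 (1.06 log units; beyond the scatter), a large step that places compound 3 with compound 1 rather than with compound 2. The step of a 1.7-fold lower number from compound 1 to compound 3 (0.24 log units; within the scatter) lies within the scatter, so 2-methylphenyl and 2-methylprop-1-en-1-yl on the saturated chain carbon bound to the aromatic nitrogen cannot be told apart here. Nothing available explains why compound 2 stands apart from both other compounds.

Going by these compounds, whether the low number of compound 2 goes with the methyl branch on the carbon bound to the nitrogen or with the saturated chain as such stays open. Also open, on these data alone, is how a straight hexyl chain or an unsubstituted benzyl group would read in this assay.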